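Amide Nitrogen Variation and Paw Edema Inhibition

The source may hold more compounds than are shown below. What is called first, only, known or untested is meant among the compounds shown, and "the series" means these compounds.

Compound 1, `COc1cc2c(cc1OC)C(CC(N)=O)CC2`: 30.4%
Compound 2, `CNC(=O)CC1CCc2cc(OC)c(OC)cc21`: 29%
Compound 3, `COc1cc2c(cc1OC)C(CC(=O)NC(C)C)CC2`: 30.4%

In a functional assay on the whole organism (strain Wistar) for inhibition, with Rattus norvegicus as the target, read by paw edema, with stated times of 60 min and 3 h, at a dose of 100 mg/kg by the oral route (on this read-out higher numbers stand for more inhibition at the one dose given (going by the name of the read-out) and lower numbers for less inhibition), compound 1 gives 30.4%. Compound 2 gives 29%, and compound 3 gives 30.4%. Compound 3 thus matches compound 1 at the digits shown and the two sit together at the top of the three numbers, but every gap among the three lies within the scatter: a number 1.4 percentage points lower from compound 1 to compound 2 (within the scatter), no change at the digits printed from compound 1 to compound 3 (within the scatter) and a number 1.4 percentage points higher from compound 2 to compound 3 (within the scatter).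

Compound 4, `COc1cc2c(cc1OC)C(CC(=O)N1CCCC1)CC2`, has not yet been measured in this assay. It differs from compound 3 at the amide nitrogen: pyrrolidin-1-yl in place of isopropylamino on a carbonyl carbon. All three measured steps change the substituent on an amide-type nitrogen and none moved the read-out beyond the scatter. Going by the values given here, the change to compound 4 goes one step further, since the hydrogen-bond donor of the isopropylamino group is lost, and no measured pair tests that loss. On the measured steps alone, no step beyond the scatter is expected, so compound 4 is estimated at 29% in this assay, within 17% to 41%. On these data alone, this estimate means a number 1.4 percentage points lower from compound 3 to compound 4 (within the scatter), with the range widened because the removal of the donor is untested.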

Compound 4, a percentage reported as inhibition, in the whole organism at one dose (the size of the read-out at that dose, not a potency): 26.1%
Estimate against measurement, compound 4: 2.9 percentage points above; measured number inside the range.
By their numbers in this assay, from the lowest: compounds 4, 2, 1 and 3 (each within the scatter of the next).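

Pyrrolidin-1-yl in place of isopropylamino on a carbonyl carbon takes away the hydrogen-bond donor of the amide and brings in a five-membered non-aromatic ring, and in this assay this change gives a number 4.3 percentage points lower from compound 3 to compound 4 (within the scatter) and so stays inside the usual spread of repeats. The comparisons with the two other amides read alike, with a number 2.9 percentage points lower from compound 2 to compound 4 (within the scatter) and a number 4.3 percentage points lower from compound 1 to compound 4 (within the scatter) as the printed steps, so among these four compounds neither the loss of the amide hydrogen nor the closing of the ring on the nitrogen separates compound 4 from the rest at this one dose. Nothing on hand bears on what lies behind this result.

All four compounds keep a carbonyl with a nitrogen on it at this place, so they leave open whether a carboxylic acid there, a morpholine ring on the carbonyl carbon or a longer chain leading to the carbonyl would give a number outside the scatter. They also leave open how these amides would compare at other doses, since a reading at one dose is not a potency.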